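Dropping a Methyl Group: One Change Tried in Two Settings

The source may hold more compounds than are shown below. What is called first, only, known or untested is meant among the compounds shown, and "the series" means these compounds.

Compound 1 `N/C(=N\NC(=S)N1CCCCCC1)c1ccccn1` was tested in a functional assay on MCF7 cells (Homo sapiens) for cytotoxicity, read by MTT assay, with a stated time of 72 h, tested at 30 uM (a higher number here means more inhibition of growth at the concentration tested, a lower number less inhibition of growth), where compound 1 gives 76.5%. Compound 3 `Cc1cccc(/C(N)=N/NC(=S)N2CCCCCC2)n1` gives 38.8% in this assay. The two differ only by hydrogen in place of methyl on an aromatic carbon, and that step is a number 37.7 percentage points higher from compound 3 to compound 1 (beyond the scatter). Compound 2 `Cc1ccnc(/C(N)=N/NC(=S)N2CCN(c3ccccn3)CC2)c1` gives 63.8%; how its core differs from the core of compound 3 is not broken down here. Compound 4 `N/C(=N\NC(=S)N1CCN(c2ccccn2)CC1)c1ccccn1` has not yet been measured and differs from compound 2 by hydrogen in place of methyl on an aromatic carbon. The surroundings are not identical: in compound 3 the methyl sits next to the ring nitrogen, in compound 2 opposite the ring nitrogen, so this is the same kind of change, not the same. An upward step is expected because the step of a number 37.7 percentage points higher from compound 3 to compound 1 (beyond the scatter) was large, though compound 2 already stands closer to compound 1. The step of a number 8.2 percentage points higher from compound 2 to compound 4 (within the scatter) is therefore expected to be smaller. Compound 4 is estimated at 72%, between 58% and 85%.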

Compound 4, percent growth inhibition at one concentration: 65.3%
Estimate against measurement, compound 4: 6.7 percentage points above; measured number inside the range.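

In this assay, hydrogen in place of methyl on this core gives a number 1.5 percentage points higher from compound 2 to compound 4 (within the scatter). The same change therefore did not carry over with the same size from one core to the other: the same change on two cores in this assay, a number 37.7 percentage points higher (beyond the scatter) from compound 3 to compound 1 and a number 1.5 percentage points higher (within the scatter) from compound 2 to compound 4, 36.2 percentage points apart, beyond the scatter of two such steps

Going by these compounds alone, with only two pairs, and the methyl in a different place on the ring in each, this does not show whether the place of the methyl or the rest of the core governs the size of the step.

The compounds shown carry only methyl or hydrogen on this ring, leaving open how an ethyl group, a methoxy group or an amine would behave on either core. Also open, from the compounds shown here alone, is what a methyl opposite the ring nitrogen would do on the core of compound 1.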